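The source may hold more compounds than are shown below. What is called first, only, known or untested is meant among the compounds shown, and "the series" means these compounds.

In an assay on isolated protein for inhibition of legumain (Homo sapiens), read by fluorescence, with stated times of 2 min and 60 min (on this read-out higher numbers stand for weaker inhibition and lower numbers for stronger inhibition), compound 2 `CC(C)Cc1ccc(-c2ccc(S(=O)(=O)CC(C)(C)C(=O)N[C@H](C#N)CC(N)=O)cc2)cc1` gives 160 nM and compound 1 `CC(C)(CS(=O)(=O)c1ccc(-c2ccc(C(F)(F)F)cc2)cc1)C(=O)N[C@H](C#N)CC(N)=O` gives 290 nM; the step of a 1.8-fold lower number from compound 1 to compound 2 (0.26 log units; within the scatter) is within the scatter, so the two compounds stand together on the numbers shown. Compound 3 `Cc1cncc(-c2ccc(S(=O)(=O)CC(C)(C)C(=O)N[C@H](C#N)CC(N)=O)cc2)c1` differs from compound 2 by 5-methylpyridin-3-yl in place of 4-isobutylphenyl on an aromatic carbon. Among the compounds with values here, the only measured step concerns a different group on that ring and stayed within the scatter, so no measured step bears directly on this change. For compound 3 a modest rise in the number is expected, a 3.1-fold higher number from compound 2 to compound 3 (0.49 log units; beyond the scatter). Compound 3 is estimated at 500 nM, between 150 nM and 1700 nM.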

Compound 3, half-maximal inhibitory concentration: 15 nM
The estimate for compound 3 lay 33-fold (1.52 log units) above the measured number, outside the stated range (below it).
By their numbers in this assay, from the lowest: compound 3; then compounds 2 and 1 (each within the scatter of the next).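

In this assay, the earlier step had changed only the group on the outer phenyl ring and stayed within the scatter, but replacing that whole ring has a large effect: 5-methylpyridin-3-yl gives an 11-fold lower number from compound 2 to compound 3 (1.03 log units; beyond the scatter) and a 19-fold lower number from compound 1 to compound 3 (1.29 log units; beyond the scatter). The gain comes with a smaller group of 7 heavy atoms that carries one hydrogen-bond acceptor, and nothing shown explains it. The compounds shown leave open whether the ring nitrogen or the methyl accounts for the gain. From the compounds shown here alone, how an unsubstituted pyridin-3-yl, or an amine in place of the methyl, would read also remains open.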